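The source may hold more compounds than are shown below. What is called first, only, known or untested is meant among the compounds shown, and "the series" means these compounds.

Measured compounds:
- compound 1, `CCN(c1ccnc(Nc2ccc(C#N)cc2)n1)c1c(F)cc(-c2ccc(C#N)cc2)cc1F`: 105000 nM
- compound 2, `CC(C)CN(c1ccnc(Nc2ccc(C#N)cc2)n1)c1c(F)cc(-c2ccc(C#N)cc2)cc1F`: 241000 nM
- compound 3, `CCC(C)N(c1ccnc(Nc2ccc(C#N)cc2)n1)c1c(F)cc(-c2ccc(C#N)cc2)cc1F`: 217000 nM

All three were tested in an ADME assay on MT4 cells (Homo sapiens) for cytotoxicity, read by MTT assay, with a stated time of 5 days; on this read-out higher numbers stand for lower toxicity in this test and lower numbers for higher toxicity in this test. Compound 2 gives the highest of the three numbers; compound 3 sits within the scatter of it, as the step of a 1.1-fold lower number from compound 2 to compound 3 (0.05 log units; within the scatter) shows, while compound 1 lies furthest away, with the step of a 2.3-fold higher number from compound 1 to compound 2 (0.36 log units; beyond the scatter).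

Compound 4, `N#Cc1ccc(Nc2nccc(N(CCCO)c3c(F)cc(-c4ccc(C#N)cc4)cc3F)n2)cc1`, has not yet been measured. It differs from compound 2 by a single change: 2-hydroxyethyl in place of isopropyl on a saturated chain carbon bound to a nitrogen on an aromatic ring. Cut one bond further out, the same difference reads isobutyl to 3-hydroxypropyl.

The measured steps only partly bear on this change. The steps of a 2.3-fold higher number from compound 1 to compound 2 (0.36 log units; beyond the scatter) and a 2.1-fold higher number from compound 1 to compound 3 (0.32 log units; beyond the scatter) show that lengthening the chain on the nitrogen raised the number modestly, and a 1.1-fold lower number from compound 2 to compound 3 (0.05 log units; within the scatter) shows that the shape of a chain of equal size made no difference beyond the scatter. Going by the values given here, no measured pair carries an oxygen into this chain, so nothing is known here about what a 2-hydroxyethyl group does in this assay. The expected outcome is therefore a small step, most likely downward toward compound 1, roughly a 1.6-fold lower number from compound 2 to compound 4 (0.21 log units; within the scatter). For compound 4 the estimate is 150000 nM, with a range from 70000 nM to 350000 nM.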

Compound 4, half-maximal cytotoxic concentration: 68000 nM
Compound 4: the middle estimate sits 2.2-fold (0.34 log units) above what was measured; measured number outside the range, below it.
By their numbers in this assay, from the lowest: compounds 4 and 1 (each within the scatter of the next); then compounds 3 and 2 (each within the scatter of the next).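

The earlier compounds shown here carried only carbon in this chain, and there the longer isobutyl and sec-butyl chains gave higher numbers than ethyl. In this assay, 3-hydroxypropyl, whose 2-hydroxyethyl part brings one hydrogen-bond donor and one hydrogen-bond acceptor, gives lower numbers, which here means higher toxicity in this test, than either carbon-only chain (a 3.5-fold lower number from compound 2 to compound 4 (0.55 log units; beyond the scatter); a 3.2-fold lower number from compound 3 to compound 4 (0.50 log units; beyond the scatter)), while against the ethyl chain the step stays within the scatter (a 1.5-fold lower number from compound 1 to compound 4 (0.19 log units; within the scatter)), so at this place chain length alone does not set the number. Nothing measured here accounts for what the hydroxyl-bearing chain does to the number.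

The compounds shown leave open whether another group at the end of this chain, such as a methyl ether, an amine or a carboxylic acid, would lower the number in the same way. They also leave open whether the hydroxyl would have the same effect on a shorter or a longer chain, which would show how much depends on the hydroxyl itself and how much on where it sits.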